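The source may hold more compounds than are shown below. What is called first, only, known or untested is meant among the compounds shown, and "the series" means these compounds.

Measured compounds:
compound 1 `Cc1cc(S(=O)(=O)/N=C(\N)n2nccc2-c2ccccc2)c(SCc2ccccc2)cc1Cl`, 5000 nM
compound 2 `Cc1cc(-c2ccccc2)n(/C(N)=N/S(=O)(=O)c2cc(C)c(Cl)cc2SCc2ccccc2)n1`, 5000 nM
compound 3 `Cc1cc(-c2ccccc2)n(/C(N)=N/S(=O)(=O)c2cc(C)c(Cl)cc2SCc2ccccc2C)n1`, 160000 nM

In a functional assay on HeLa cells (Homo sapiens) for cytotoxicity, read by MTT assay, with a stated time of 72 h (on this read-out lower numbers stand for stronger inhibition and higher numbers for weaker inhibition), compound 1 stands level with compound 2 and the two together give the lowest numbers of the three; compound 3 sits far apart, as a 32-fold higher number from compound 2 to compound 3 (1.51 log units; beyond the scatter) shows, whereas no change at the digits printed from compound 1 to compound 2 (within the scatter) is flat. Compound 4 `Cc1cc(S(=O)(=O)/N=C(\N)n2nccc2-c2ccccc2)c(SCc2ccccc2C(F)(F)F)cc1Cl` arises from compound 1 by trifluoromethyl in place of hydrogen on an aromatic carbon, that is, on the benzylsulfanyl phenyl ring ortho to a large group. Among the measured compounds shown here, the step that bears on it is the one from compound 2 to compound 3, which put a methyl on that same ring and was large; the pyrazole methyl step does not inform it. A large rise in this assay is therefore expected, a 30-fold higher number from compound 1 to compound 4 (1.48 log units; beyond the scatter), giving compound 4 an estimated 150000 nM with a range from 30000 nM to 600000 nM.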

Compound 4, half-maximal inhibitory concentration: 20000 nM
For compound 4 the middle estimate is 7.5-fold (0.88 log units) above the measured one; measured number below the stated range.
By their numbers in this assay, from the lowest: compounds 1 and 2 (each within the scatter of the next); then compound 4; then compound 3.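

In this assay, trifluoromethyl on this aromatic carbon gives a 4.0-fold higher number from compound 1 to compound 4 (0.60 log units; beyond the scatter) and so still raises the number, but only modestly. The methyl step on the same ring, a 32-fold higher number from compound 2 to compound 3 (1.51 log units; beyond the scatter) on a different parent, was large, which shows that substitution on this ring need not bring a large rise. Nothing available here accounts for this difference in size. It remains open whether the group or the parent sets the size of the rise, since methyl on compound 1 and trifluoromethyl on compound 2 are not among the compounds shown. As far as these compounds go, how an amine or a methoxy group on this carbon would read also remains open.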